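A few compounds are considered here, and "the series" means these few. Any claim that something is new, unique, unknown or untested is made for them only; others in the source may bear on it.

The series shares one core. Compound 1 `COc1cc(Cl)cc(-c2nn(-c3cccc(NC(=O)Nc4ccc(Cl)c(C(F)(F)F)c4)c3)cc2-c2ccncc2)c1` gives -68% in a functional assay on BT-549 cells (Homo sapiens) for inhibition, read by sulforhodamine B assay, with a stated time of 48 h, tested at 100 uM (a lower number here means a stronger effect, a higher number a weaker effect of the compound at the concentration tested), compound 2 `COc1cc(Cl)cc(-c2nn(-c3cccc(NC(=O)Nc4ccc(Cl)c(Cl)c4)c3)cc2-c2ccncc2)c1` gives -15%, and compound 3 `COc1cc(Cl)cc(-c2nn(-c3cccc(NC(=O)Nc4cccc(C(F)(F)F)c4)c3)cc2-c2ccncc2)c1` gives -48%. Compound 3 thus stands second highest of the three: a number 20 percentage points higher from compound 1 to compound 3 (beyond the scatter) separates it from its nearest neighbour, while a number 33 percentage points lower from compound 2 to compound 3 (beyond the scatter) separates it from compound 2. Compound 4 `COc1cc(Cl)cc(-c2nn(-c3cccc(NC(=O)c4cccc(C(F)(F)F)c4)c3)cc2-c2ccncc2)c1` differs from compound 3 by 3-(trifluoromethyl)phenyl in place of (3-(trifluoromethyl)phenyl)amino on a carbonyl carbon. Within the data shown here, none of the measured steps touches that carbonyl carbon; all three vary only the outer aromatic ring, so no step directly bears on this change. The expected outcome is therefore uncertain, and a change no larger than the scatter, or at most modest, is anticipated: a number 13 percentage points higher from compound 3 to compound 4 (beyond the scatter). Compound 4 is estimated at -35%, within -70% to 5%.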

Compound 4, a percentage reported as activity, at one concentration (the size of the read-out at that concentration, not a potency): 54%
Estimate against measurement, compound 4: 89 percentage points below; the measured number lies above the stated range.
By their numbers in this assay, from the lowest: compound 1; then compound 3; then compound 2; then compound 4.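

In this assay, among these compounds, the earlier steps varied only the outer aromatic ring, whereas this change on the carbonyl carbon removes the amino nitrogen and gives a number 102 percentage points higher from compound 3 to compound 4 (beyond the scatter) with a weaker effect. The same change separates compound 4 from the other two compounds as well, with a number 69 percentage points higher from compound 2 to compound 4 (beyond the scatter) and a number 122 percentage points higher from compound 1 to compound 4 (beyond the scatter) in the same direction. No measurement shown accounts for this shift. Still open, as far as these compounds go, is how the 4-chloro-3-(trifluoromethyl)phenyl group would behave directly on the carbonyl carbon, and what a methylene group would do in place of the amino nitrogen.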